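Extending the Oxime Ether of Compound 2 with an Oxazole

The source may report more compounds than this note shows. Statements on the series, on what has been measured and on what is new or still open speak of the compounds shown alone.

Compound 1, `OC1O[C@H](CO/N=C2\CCc3cc(Sc4cc(F)cc(C5CCOCC5)c4)ccc32)[C@H](O)[C@H](O)[C@H]1O`, is reported only as a limit of the assay, > 2500 nM in a functional assay (blood) for inhibition, with Homo sapiens as the target (a higher number here means a weaker inhibitor, a lower number a stronger inhibitor), not as a number.
Compound 2, `CO/N=C(\C)c1ccc(Sc2cc(F)cc(C3CCOCC3)c2)cc1`, gives 110 nM in this assay.
Compound 3, `CS/C(=N\O)c1ccc(Sc2cc(F)cc(C3CCOCC3)c2)cc1`, gives 190 nM in this assay.

Among the two numbers shown, compound 2 has the lowest, and its nearest neighbour is compound 3, with a 1.7-fold higher number from compound 2 to compound 3 (0.24 log units; within the scatter). Compound 4, `COC(=O)c1cc(CO/N=C(\C)c2ccc(Sc3cc(F)cc(C4CCOCC4)c3)cc2)on1`, has not yet been measured. It differs from compound 2 in a single place: 3-(methoxycarbonyl)-1,2-oxazol-5-yl in place of hydrogen on a saturated chain carbon bound to an oxygen on an unsaturated carbon. No measured step covers this kind of change; the only step shown, from compound 2 to compound 3, swaps one small group on the oxime carbon and stays within the scatter. Compound 1 carries a much larger group on the same kind of chain carbon, and its value is only a limit. Because of the limit of > 2500 nM in this assay, at which 1 of the 3 values shown sits, a larger group here is taken as a risk for a weaker result. The step to compound 4 is therefore expected to be a 3.6-fold higher number from compound 2 to compound 4 (0.56 log units; beyond the scatter), towards a higher number. Compound 4 is estimated at 400 nM, with a range from 120 nM to 1500 nM.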

Compound 4, half-maximal inhibitory concentration: 100 nM
Compound 4: the middle estimate sits 4.0-fold (0.60 log units) above what was measured; measured number outside the range, below it.
By their numbers in this assay, from the lowest: compounds 4, 2 and 3 (each within the scatter of the next). At a limit, above all of these: compound 1.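

In this assay, putting 3-(methoxycarbonyl)-1,2-oxazol-5-yl in place of hydrogen on a saturated chain carbon bound to an oxygen on an unsaturated carbon gives a 1.1-fold lower number from compound 2 to compound 4 (0.04 log units; within the scatter). This is the first single change shown at this place, and it shows that a group with one five-membered aromatic ring can sit here while the two compounds read alike. Compound 1 differs from compound 4 in more than one place, so its limit does not speak to this single change: the limit of > 2500 nM in this assay, at which 1 of the 4 values shown sits.

The compounds shown do not tell whether the ring or its methoxycarbonyl group matters more, or how a carboxylic acid or a primary amide in place of that methoxycarbonyl would read in this assay. As far as these compounds go, how a plain phenyl ring or a longer alkyl chain at this place would read also stays open.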